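Compound 3 to compound 4: cyclopropylmethyl to 4-fluorobenzyl

The source may report more compounds than this note shows. Statements on the series, on what has been measured and on what is new or still open speak of the compounds shown alone.

Of the compounds shown here, three on one shared core have been read so far in a functional assay on HeLa cells (Homo sapiens) for antiproliferative activity, read by MTT assay, with a stated time of 48 h (a lower number here means a stronger inhibitor, a higher number a weaker inhibitor), and only one gives a number. Compound 1 (`Cn1cc(-c2cnc3ccnc(NC(=O)c4cccnc4)c3c2)cn1`) reads > 50000 nM and this is a limit of the assay. Compound 2 (`CCNc1nccc2ncc(-c3cnn(C)c3)cc12`) reads > 50000 nM and this too is a limit. Going by the values given here, compound 3 (`Cn1cc(-c2cnc3ccnc(NCC4CC4)c3c2)cn1`) reads 7400 nM and is the only true number.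

The next change leads to compound 4 (`Cn1cc(-c2cnc3ccnc(NCc4ccc(F)cc4)c3c2)cn1`), with 4-fluorophenyl in place of cyclopropyl on a saturated chain carbon bound to a nitrogen on an aromatic ring.

The closest measured step is an at least 6.7-fold lower number from compound 2 to compound 3 (0.82 log units; beyond the scatter) at this same place, with cyclopropyl in place of methyl. The step of an at least 6.7-fold lower number from compound 1 to compound 3 (0.82 log units; beyond the scatter) is a less direct guide, since it replaces (pyridin-3-yl)carbonyl on the nitrogen. Both are bounded by limits, and a step that the two limits leave unreadable from compound 1 to compound 2 gives no size at all. Among the compounds with values here, no measured compound carries an aromatic ring at this place.

Resting on an at least 6.7-fold lower number from compound 2 to compound 3 (0.82 log units; beyond the scatter) as a single pair, a lower number is expected, though only a small further move. The expected change is a 2.1-fold lower number from compound 3 to compound 4 (0.33 log units; beyond the scatter) in this assay and it remains uncertain. For compound 4 the estimated value is 3500 nM with an expected range of 800 nM to 20000 nM in this series.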

Compound 4, half-maximal inhibitory concentration: 9200 nM
Beside the measured number, compound 4's estimate is 2.6-fold (0.42 log units) below it; the measured number falls inside the stated range.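

In this assay, replacing cyclopropyl with 4-fluorophenyl on the saturated chain carbon bound to a nitrogen on an aromatic ring gives a 1.2-fold higher number from compound 3 to compound 4 (0.09 log units; within the scatter), so this place accepts a six-membered aromatic ring as well as a three-membered non-aromatic ring, with no readable difference between the two. The same position now has two groups that separate from the limit compounds, with an at least 5.4-fold lower number from compound 2 to compound 4 (0.73 log units; beyond the scatter) and an at least 5.4-fold lower number from compound 1 to compound 4 (0.73 log units; beyond the scatter), and the earlier series offered only cyclopropylmethyl as a measured example. The true sizes of these two steps stay unknown because compound 1 and compound 2 each rest on a limit rather than a number: the limit of > 50000 nM in this assay, at which 2 of the 4 values shown sit.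

On these data alone, the role of the fluorine remains open, and a plain benzyl or a 4-methoxybenzyl at this place would separate it from that of the aromatic ring. Also open, as far as these compounds go, is whether any group here can move the reading beyond the scatter around compound 3 and compound 4, as a longer chain such as n-butyl or a chain ending in an amine might test.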